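A few compounds are considered here, and "the series" means these few. Any claim that something is new, unique, unknown or untested is made for them only; others in the source may bear on it.

Measured so far:
compound 1 `Cc1ccsc1-c1cc(-c2ccco2)cc(-c2ccccc2Cl)n1`: 2%
compound 2 `Cc1ccsc1-c1cc(-c2ccco2)cc(-c2ccc(Cl)cc2)n1`: 1%

In an assay on isolated protein for inhibition of DNA topoisomerase 1 (Homo sapiens), with a stated time of 30 min, tested at 100 uM (a lower number here means less inhibition, a higher number more inhibition at the concentration tested (going by the name of the read-out)), compound 1 gives 2%. In this assay compound 2 gives 1%. Compound 2 sits alongside compound 1, since the step of a number 1 percentage points lower from compound 1 to compound 2 (within the scatter) lies within the usual scatter; both compounds show almost no inhibition at the tested concentration.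

Compound 3 `Clc1ccc(-c2cc(-c3ccco3)cc(-c3ccc(Cl)s3)n2)cc1` is not yet measured. Its structure differs from compound 2 in one place: 5-chlorothiophen-2-yl in place of 3-methylthiophen-2-yl on an aromatic carbon.

Within the data shown here, only one measured step exists, and it concerns a different group on the shared core, the swap of 2-chlorophenyl for 4-chlorophenyl, which gave a number 1 percentage points lower from compound 1 to compound 2 (within the scatter) and stayed within the scatter. Among the measured compounds shown here, no measured step touches the thiophene ring that is exchanged here, so the data give no direct guide to this change. Both measured compounds lie near zero, and a move to a value far from them would need evidence the numbers do not hold. The step of a number 1 percentage points higher from compound 2 to compound 3 (within the scatter) is therefore expected to stay within the scatter. For compound 3 the expected result in this assay is 2%, with a range from -5% to 12%.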

Compound 3, a percentage reported as inhibition, at one concentration (the size of the read-out at that concentration, not a potency): 53.1%
The estimate for compound 3 lay 51.1 percentage points below the measured number, and the stated range ends below it.
By their numbers in this assay, from the lowest: compounds 2 and 1 (each within the scatter of the next); then compound 3.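

In this assay, the group on the aromatic carbon next to the ring nitrogen proves to matter far more than the two near-zero compounds suggested: 5-chlorothiophen-2-yl in place of 3-methylthiophen-2-yl gives a number 52.1 percentage points higher from compound 2 to compound 3 (beyond the scatter) and moves the series clearly away from almost no inhibition. The size of this step stands out. The two groups look alike in the computed counts: each is one five-membered aromatic ring with 1 hetero atom, and the numbers of heavy atoms, hydrogen-bond donors and hydrogen-bond acceptors match. No measurement at hand bears on why this exchange has such an effect.

The methyl group leaves and the chlorine enters in the same step, so the compounds shown cannot separate the effect of gaining the chlorine from that of losing the methyl, or from that of where the substituent sits on the thiophene. Also open, as far as these compounds go, is how plain thiophen-2-yl, 5-bromothiophen-2-yl or 5-methylthiophen-2-yl would behave here, and whether 5-chlorothiophen-2-yl would give similar inhibition alongside the 2-chlorophenyl group of compound 1.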